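The compounds below may be only part of what the source reports. "The series", "measured", "known", "first", "only" and "open" are said of these compounds alone.

Working notes on the aryl group of the series. Compound 1 (`CCOC(=O)c1c(-c2ccc(OC)cc2)[nH]c2cccc(OC)c2c1=O`) gives > 100000 nM in a physicochemical assay for solubility, in phosphate buffer, at pH 7.4 (on this read-out lower numbers stand for lower solubility and higher numbers for higher solubility), as a limit, not a number. Compound 2 (`CCOC(=O)c1c(-c2cccc(F)c2)[nH]c2cccc(OC)c2c1=O`) gives > 100000 nM here, also a limit. Compound 3 (`CCOC(=O)c1c(-c2ccccc2C)[nH]c2cccc(OC)c2c1=O`) gives > 100000 nM here, again a limit. Compound 3 therefore has no number, only the reading shared across the series (the limit of > 100000 nM in this assay, at which 3 of the 3 values shown sit).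

The change to compound 4 (`CCOC(=O)c1c(-c2cccc(OC)c2)[nH]c2cccc(OC)c2c1=O`) puts 3-methoxyphenyl in place of 2-methylphenyl on an aromatic carbon, next to the ring nitrogen and ortho to an ethoxycarbonyl group (3-methoxyphenyl in place of 2-methylphenyl on an aromatic carbon).

Three measured exchanges at this same carbon bear on it, namely a step that the two limits leave unreadable from compound 1 to compound 2 and a step that the two limits leave unreadable from compound 1 to compound 3 and also a step that the two limits leave unreadable from compound 2 to compound 3 with no size to read in any of them. They offer no direction for the new step. The closest comparison is compound 1, a methoxyphenyl analogue, whose > 100000 nM reading is a limit. The step is estimated as a number no higher from compound 3 to compound 4 (the limit leaves the size open) in this assay and nothing beyond the scatter is expected. For compound 4 the expected value is 100000 nM with an estimated range from 50000 nM to 200000 nM and a reading as a limit is the likelier outcome.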

Compound 4, solubility: > 100000 nM
Compound 4: no number, only a limit (the forecaster's own chance of this, stated with the estimate: 85%); the middle value sits exactly at the limit.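

In this assay compound 4 gives > 100000 nM as a limit, not a number. Going by these compounds alone, no step from compound 1, compound 2 or compound 3 to compound 4 can be read, and the series shares one reading: the limit of > 100000 nM in this assay, at which 4 of the 4 values shown sit. The compounds shown leave open whether any of these aryl groups gives a reading under that limit, and how the four compounds compare.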